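This account rests on a few compounds, and the source may have more. Where it says the series, first, only, none or still open, it means among the compounds named here.

Compound 2 `O=C1c2c[n+]([O-])c3ccccc3c2C(=O)c2c1c1ccccc1n2CCCCN1CCCCC1` gives 610 nM in a functional assay on MDA-MB-231 cells (Homo sapiens) for cytotoxicity, read by MTT assay, with a stated time of 72 h; a lower number here means a stronger inhibitor, a higher number a weaker inhibitor. Going by the values given here, of the two numbers measured so far, this is the lower one: compound 1 `O=C1c2c[n+]([O-])c3ccccc3c2C(=O)c2c1c1ccccc1n2Cc1cn([C@H]2O[C@H](CO)[C@@H](O)[C@H]2O)nn1` gives 1700 nM in this assay, and the gap between the two lies beyond the usual scatter. Compound 3 `O=C1c2c[n+]([O-])c3ccccc3c2C(=O)c2c1c1ccccc1n2CCN1CCCCC1` is the compound not yet measured, and it differs from compound 2 in a single place: piperidin-1-yl in place of 2-(piperidin-1-yl)ethyl on a saturated chain carbon, two bonds along the chain from an aromatic nitrogen. Among the compounds with values here, no pair of measured compounds shows a step of this kind, so the two numbers in hand say nothing direct about what a shorter chain does here. The step of a 1.5-fold higher number from compound 2 to compound 3 (0.17 log units; within the scatter) is expected to be modest, leaning toward a somewhat higher number but not clearly outside the scatter. Compound 3 is accordingly expected to give 900 nM in this assay, with a likely range from 300 nM to 2700 nM.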

Compound 3, half-maximal inhibitory concentration: 1050 nM
Compound 3: the middle estimate sits 1.2-fold (0.07 log units) below what was measured; the range from low to high includes it.
By their numbers in this assay, from the lowest: compounds 2, 3 and 1 (each within the scatter of the next, the first and the last beyond it).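

In this assay, cutting the 4-(piperidin-1-yl)butyl chain back to the 2-(piperidin-1-yl)ethyl chain gives a 1.7-fold higher number from compound 2 to compound 3 (0.24 log units; within the scatter). This is the first direct reading of chain length at this place, and it shows that, for this pair, the change does not move the result beyond the scatter, so the 4-(piperidin-1-yl)butyl length is not shown to be required for this cytotoxicity. No measurement shown here bears on what lies behind this result.

As far as these compounds go, a single pair cannot establish a trend with chain length, so it remains open how a 3-(piperidin-1-yl)propyl or (piperidin-1-yl)methyl chain would read at this place. From the compounds shown here alone, it is also open whether a morpholine or a dimethylamine in place of the piperidine would keep the result within the same scatter.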